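Aryl replacement of the alkynyl arm in the ribosyl series

The source may report more compounds than this note shows. Statements on the series, on what has been measured and on what is new or still open speak of the compounds shown alone.

Measured compounds:
- compound 1, `Nc1ncnn2c([C@@H]3O[C@H](CO)[C@@H](O)[C@H]3O)cc(C#Cc3ccccc3)c12`: 37700 nM
- compound 2, `Nc1ncnn2c([C@@H]3O[C@H](CO)[C@@H](O)[C@H]3O)cc(-c3ccc(Cl)cc3)c12`: 56700 nM
- compound 3, `Nc1ncnn2c([C@@H]3O[C@H](CO)[C@@H](O)[C@H]3O)cc(-c3ccc(F)cc3F)c12`: 50900 nM

All three were run in a functional assay on CAPAN-1 cells (Homo sapiens) for antiproliferative activity, with a stated time of 72 h; a lower number here means a stronger inhibitor, a higher number a weaker inhibitor. Compound 1 gives the lowest of the three numbers, but its steps to the other two are small: a 1.5-fold higher number from compound 1 to compound 2 (0.18 log units; within the scatter) and a 1.4-fold higher number from compound 1 to compound 3 (0.13 log units; within the scatter). The two aryl analogues also sit together, a 1.1-fold lower number from compound 2 to compound 3 (0.05 log units; within the scatter). Within these three compounds, then, swapping the 2-phenylethynyl arm for a substituted phenyl has produced no step beyond the scatter.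

Compound 4, `Nc1ncnn2c([C@@H]3O[C@H](CO)[C@@H](O)[C@H]3O)cc(-c3ccccc3Cl)c12`, has not yet been measured. It differs from compound 1 as follows: 2-chlorophenyl in place of 2-phenylethynyl on an aromatic carbon. The change is of the same kind as the two measured steps from compound 1, a halogenated phenyl entering where the 2-phenylethynyl group leaves; both of those steps stayed within the scatter. The expectation for compound 4 is therefore a number close to those of compounds 2 and 3, and the step of a 1.3-fold higher number from compound 1 to compound 4 (0.12 log units; within the scatter) is expected to remain within the scatter. Compound 4 is estimated at 50000 nM, with a range from 20000 nM to 120000 nM.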

Compound 4, half-maximal inhibitory concentration: 54900 nM
The estimate for compound 4 lay 1.1-fold (0.04 log units) below the measured number; the measured number falls inside the stated range.
By their numbers in this assay, from the lowest: compounds 1, 3, 4 and 2 (each within the scatter of the next).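

Among these compounds, in (this assay), compound 4 gives the first comparison of a single chlorine at two places on the phenyl ring, 2-chlorophenyl against 4-chlorophenyl, and that step (a 1.0-fold lower number from compound 2 to compound 4 (0.01 log units; within the scatter)) separates nothing. Replacing 2,4-difluorophenyl with 2-chlorophenyl (a 1.1-fold higher number from compound 3 to compound 4 (0.03 log units; within the scatter)) reads the same way, and a third halogenated phenyl in place of 2-phenylethynyl (a 1.5-fold higher number from compound 1 to compound 4 (0.16 log units; within the scatter)) again gives no step beyond the scatter at this position. No measurement on hand offers a cause for this flat picture.

Open, from the compounds shown here alone, is whether a basic amine or a carboxylic acid on the phenyl ring, or a longer alkyl chain in place of the aryl group, would give a step beyond the scatter. Also open, going by these compounds, is whether any such step depends on the 3,4-dihydroxy-5-(hydroxymethyl)oxolan-2-yl group shared by all four compounds.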